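The source may hold more compounds than are shown below. What is called first, only, known or untested is meant among the compounds shown, and "the series" means these compounds.

Measured set in an assay on isolated protein for agonist activity at Bile acid receptor (Homo sapiens), read by AlphaScreen, with a stated time of 30 min; a higher number here means that more compound is needed for the effect, a lower number that less compound is needed:
- compound 1 `CCc1ccccc1-n1nc(C)c2c1NC(=O)[C@H](C)S[C@@H]2c1ccc(Oc2ccccc2)cc1`: 1100 nM
- compound 2 `Cc1ccc(-n2nc(C)c3c2NC(=O)[C@H](C)S[C@@H]3c2ccc(Oc3ccccc3)cc2)cc1`: 3400 nM
- compound 3 `Cc1nn(-c2ccccc2C(C)C)c2c1[C@@H](c1ccc(Oc3ccccc3)cc1)S[C@@H](C)C(=O)N2`: 1900 nM

Compound 3 gives the second highest of the three numbers in this assay. Its nearest neighbour is compound 1, a 1.7-fold higher number from compound 1 to compound 3 (0.24 log units; within the scatter), and its furthest is compound 2, a 1.8-fold lower number from compound 2 to compound 3 (0.25 log units; within the scatter); both gaps lie within the scatter, so the three cannot be separated on this assay.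

Compound 4 `Cc1cccc(-n2nc(C)c3c2NC(=O)[C@H](C)S[C@@H]3c2ccc(Oc3ccccc3)cc2)c1` differs from compound 3 by 3-methylphenyl in place of 2-isopropylphenyl on an aromatic nitrogen. Among the measured compounds shown here, two measured steps bear on exchanging the group on that nitrogen. a 3.1-fold higher number from compound 1 to compound 2 (0.49 log units; beyond the scatter) is the only one beyond the scatter and runs toward a higher number. a 1.8-fold lower number from compound 2 to compound 3 (0.25 log units; within the scatter) runs the other way but stays within the scatter. For the measured compounds named here, a 3-methylphenyl group occurs in none of the measured compounds, so the step is read from these two exchanges alone. For compound 4 a modest shift toward a higher number is expected, a 1.8-fold higher number from compound 3 to compound 4 (0.27 log units; within the scatter). The estimate for compound 4 is 3500 nM, with a range from 1500 nM to 8000 nM.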

Compound 4, half-maximal effective concentration: 2400 nM
Compound 4: the middle estimate sits 1.5-fold (0.16 log units) above what was measured; measured number inside the range.
By their numbers in this assay, from the lowest: compounds 1, 3, 4 and 2 (each within the scatter of the next, the first and the last beyond it).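

In this assay, 3-methylphenyl and 4-methylphenyl on the aromatic nitrogen cannot be separated (a 1.4-fold lower number from compound 2 to compound 4 (0.15 log units; within the scatter)), and neither can 3-methylphenyl and 2-isopropylphenyl (a 1.3-fold higher number from compound 3 to compound 4 (0.10 log units; within the scatter)). Against 2-ethylphenyl the step is beyond the scatter (a 2.2-fold higher number from compound 1 to compound 4 (0.34 log units; beyond the scatter)), the second modest step of this kind, so 2-ethylphenyl now stands apart from both methylphenyl groups, though not from 2-isopropylphenyl. Nothing measured here accounts for these differences.

The compounds shown leave open whether any group at this nitrogen gives more than a modest step, since all four carry a phenyl ring with a single alkyl group. An unsubstituted phenyl, a pyridine ring, a 2-methoxyphenyl or a 2-chlorophenyl group would test whether this narrow spread holds beyond alkyl-substituted phenyl rings.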